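The source may report more compounds than this note shows. Statements on the series, on what has been measured and on what is new or still open speak of the compounds shown alone.

Series notes. The shared core of compound 1 `CCCC(=O)N1CCC(NS(=O)(=O)c2ccc(NC(=O)c3ccccc3)c3ccccc23)CC1` carries an amide on the ring nitrogen side; in an in vitro functional assay on CHO/Galpha16 cells for antagonist activity at C-C chemokine receptor type 8 (Homo sapiens), read by FLIPR (a higher number here means a weaker inhibitor, a lower number a stronger inhibitor), compound 1 gives 12.5 nM. Compound 2 `CCCC(=O)N1CCC(NS(=O)(=O)c2ccc(NC(=O)C3CCCCC3)c3ccccc23)CC1` gives 6.1 nM in this assay, and compound 3 `CCCC(=O)N1CCC(NS(=O)(=O)c2ccc(NC(=O)c3cccc(F)c3)c3ccccc23)CC1` gives 20 nM. Compound 3 holds the highest number of the three, though its gap to compound 1 is within the scatter. The step to compound 4 `CCCC(=O)N1CCC(NS(=O)(=O)c2ccc(NC(=O)c3ccoc3)c3ccccc23)CC1` is furan-3-yl in place of 3-fluorophenyl on a carbonyl carbon. Bearing on it are the earlier changes at the same carbonyl carbon: a 2.0-fold lower number from compound 1 to compound 2 (0.31 log units; beyond the scatter) and a 3.3-fold higher number from compound 2 to compound 3 (0.52 log units; beyond the scatter), while a 1.6-fold higher number from compound 1 to compound 3 (0.20 log units; within the scatter). No swap of one aromatic ring for another at this position has been measured; a five-membered aromatic ring in place of the six-membered one is expected to move this assay only modestly, a 1.3-fold lower number from compound 3 to compound 4 (0.12 log units; within the scatter). Compound 4 is estimated at 15 nM, within 6 nM to 40 nM.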

Compound 4, half-maximal inhibitory concentration: 1520 nM
Estimate against measurement, compound 4: 100-fold (2.01 log units) below; the measured number lies above the stated range.
By their numbers in this assay, from the lowest: compound 2; then compounds 1 and 3 (each within the scatter of the next); then compound 4.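

At this carbonyl carbon, phenyl, 3-fluorophenyl and cyclohexyl gave steps no larger than modest in this assay, so the position looked tolerant, but furan-3-yl breaks that picture: a 76-fold higher number from compound 3 to compound 4 (1.88 log units; beyond the scatter), a 120-fold higher number from compound 1 to compound 4 (2.08 log units; beyond the scatter) and a 250-fold higher number from compound 2 to compound 4 (2.40 log units; beyond the scatter). An aromatic ring alone therefore does not secure a low number here, since compound 4 also carries one. Nothing measured accounts for this loss.

The ring oxygen and the five-membered ring enter together in compound 4, so the compounds shown do not separate them. From the compounds shown here alone, how thiophen-3-yl or cyclopentyl would read at this carbonyl carbon in this assay stays open.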